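From Nitrophenyl to Fluorophenyl on the Carbonyl

The source may hold more compounds than are shown below. What is called first, only, known or untested is meant among the compounds shown, and "the series" means these compounds.

Compound 3 `CN(C(=O)NC(=O)c1ccc([N+](=O)[O-])cc1)c1nc(C(F)(F)F)c(C(=O)N/N=C/c2cccc(C(F)(F)F)c2)s1` has the lowest of the two numbers available in a functional assay on BCG823 cells (Homo sapiens) for inhibition, read by MTT assay, with a stated time of 72 h (a higher number here means a weaker inhibitor, a lower number a stronger inhibitor), namely 1.67 ug/mL. Compound 2 `CN(C(=O)NC(=O)c1ccc(F)c(F)c1)c1nc(C(F)(F)F)c(C(=O)N/N=C/c2cccc(C(F)(F)F)c2)s1` gives 4.46 ug/mL in this assay. Compound 1 `CNc1nc(C(F)(F)F)c(C(=O)N/N=C/c2cccc(C(F)(F)F)c2)s1` reaches only the limit > 100 ug/mL in this assay, so it provides no number. The change to compound 4 `CN(C(=O)NC(=O)c1ccccc1F)c1nc(C(F)(F)F)c(C(=O)N/N=C/c2cccc(C(F)(F)F)c2)s1` is 2-fluorophenyl in place of 4-nitrophenyl on a carbonyl carbon. Going by the values given here, one measured step bears on it: a 2.7-fold lower number from compound 2 to compound 3 (0.43 log units; beyond the scatter), where a fluorinated phenyl gave the higher number than the nitrophenyl. Since compound 4 again carries a fluorophenyl in place of the nitrophenyl, a modest rise of about that size is expected. Compound 4 is therefore estimated to give 3.5 ug/mL in this assay, within 1.5 ug/mL to 8 ug/mL, meaning an expected step of a 2.1-fold higher number from compound 3 to compound 4 (0.32 log units; beyond the scatter).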

Compound 4, half-maximal inhibitory concentration: 16.3 ug/mL
Estimate against measurement, compound 4: 4.7-fold (0.67 log units) below, outside the stated range (above it).
By their numbers in this assay, from the lowest: compound 3; then compound 2; then compound 4. At a limit, above all of these: compound 1.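

At this carbonyl carbon, the 2-fluorophenyl in place of 4-nitrophenyl gives in this assay a 9.8-fold higher number from compound 3 to compound 4 (0.99 log units; beyond the scatter). Fluorinated phenyls are not interchangeable here either, with a 3.7-fold higher number from compound 2 to compound 4 (0.56 log units; beyond the scatter). The acylated carbamoyl group on the nitrogen still helps, with an at least 6.1-fold lower number from compound 1 to compound 4 (0.78 log units; beyond the scatter), although compound 1 stands only at a limit: the limit of > 100 ug/mL in this assay, at which 1 of the 4 values shown sits.

The compounds leave open whether the place or the number of the fluorines separates compound 2 from compound 4, as both change at once. From the compounds shown here alone, how a plain phenyl, a 4-fluorophenyl or a 4-aminophenyl would read at this carbonyl also remains open.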